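The compounds below may be only part of what the source reports. "The series", "measured", "known", "first", "only" and "open" are said of these compounds alone.

Among the measured compounds shown here, in an in vitro functional assay on cells for agonist activity at Bombesin receptor subtype-3 (Homo sapiens), read by luminescence and calcium flux (on this read-out lower numbers stand for an effect already at smaller amounts and higher numbers for an effect only at larger amounts of compound), compound 1 `O=C(O)c1ccccc1-c1ccc(CCc2ncc(CC3CCCCC3)[nH]2)cc1` gives 41 nM, the lowest of the two numbers measured so far. For the measured compounds named here, compound 2 `O=C(O)c1ccccc1-c1ccc(CCc2ncc(Cc3ccc(F)cc3)[nH]2)cc1` gives 1600 nM; the only measured step, a 39-fold higher number from compound 1 to compound 2 (1.59 log units; beyond the scatter), shows that this assay answers strongly to what is carried on the saturated chain carbon bound to an aromatic carbon. Compound 3 `CC(C)(C)c1cnc(CCc2ccc(-c3ccccc3C(=O)O)cc2)[nH]1` has not yet been run in this assay. It differs from compound 1 by tert-butyl in place of cyclohexylmethyl on an aromatic carbon. The step from compound 1 to compound 2 bears only indirectly on this change: there a ring of one kind was exchanged for a ring of another kind, here the ring leaves altogether and a group with no ring enters. Going by the values given here, with a single large step as the only guide, a higher number for compound 3 is expected in this assay, though the data give no measure of how much a loss of the ring costs, and a step smaller than that to compound 2 seems the more plausible reading. The expected value for compound 3 is 250 nM, with a range of 60 nM to 1500 nM. The estimated step is a 6.1-fold higher number from compound 1 to compound 3 (0.79 log units; beyond the scatter).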

Compound 3, half-maximal effective concentration: 4330 nM
For compound 3 the middle estimate is 17-fold (1.24 log units) below the measured one, outside the stated range (above it).
By their numbers in this assay, from the lowest: compound 1; then compound 2; then compound 3.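

In this assay this aromatic carbon of the five-membered aromatic ring with 2 nitrogen proves even more demanding than the step to compound 2 suggested: tert-butyl in place of cyclohexylmethyl gives a 110-fold higher number from compound 1 to compound 3 (2.02 log units; beyond the scatter) and thus one of the two large steps at this place. The change also separates the two replacements, since tert-butyl in place of 4-fluorobenzyl gives a 2.7-fold higher number from compound 2 to compound 3 (0.43 log units; beyond the scatter) and so the group with no ring stands highest of the three. A ring alone does not restore the number of compound 1, as compound 2 keeps a ring and still stands well above it, while the ring in compound 2 goes with a lower number than compound 3 shows.

The change to tert-butyl removes the ring and the chain carbon together, so their shares stay unresolved; 2,2-dimethylpropyl, which keeps a chain carbon without a ring, or cyclohexyl bound directly to the aromatic carbon would divide the two. Going by these compounds, whether a longer chain such as 2-cyclohexylethyl is accepted at this place also remains open. Nothing at hand accounts for the size of these steps.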